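Sulfanyl for aminoamino on the benzyl-bearing core

This account rests on a few compounds, and the source may have more. Where it says the series, first, only, none or still open, it means among the compounds named here.

Compound 1 `NNc1nc2c(N)ncnc2n1Cc1ccccc1` sits at the limit of a functional assay (spleen, spleen) for activation, with Mus musculus as the target (a higher number here means that more compound is needed for the effect, a lower number that less compound is needed), giving > 10 uM (the limit of > 10 uM in this assay, at which 1 of the 3 values shown sits), so no number stands for it. Compound 2 `Nc1nc(N)c2nc(O)n(Cc3ccccc3)c2n1` gives 10 uM and compound 3 `CCCCNc1nc(N)c2nc(O)n(Cc3ccccc3)c2n1` gives 1 uM; the step of a 10-fold lower number from compound 2 to compound 3 (1.00 log units; beyond the scatter) is the only measured one, and it concerns a different position, so nothing measured bears on the change from compound 1 to compound 4. Compound 4 `Nc1ncnc2c1nc(S)n2Cc1ccccc1` differs by sulfanyl in place of aminoamino on an aromatic carbon. Only the limit of compound 1 frames it. Compound 4 is expected to give a number near the limit rather than another limit, estimated at 10 uM with a range from 3 uM to 30 uM. The step this estimate implies is a number no higher from compound 1 to compound 4 (the limit leaves the size open), and it is held loosely.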

Compound 4, minimum effective concentration: 10 uM
Estimate against measurement, compound 4: no gap at the digits printed; measured number inside the range.
By their numbers in this assay, from the lowest: compound 3; then compounds 2 and 4 (each within the scatter of the next).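

At this carbon, between two ring nitrogen atoms, sulfanyl in place of aminoamino gives a number no higher from compound 1 to compound 4 (the limit leaves the size open) in this assay. Compound 1 stands at a limit, so the size of this step cannot be read: the limit of > 10 uM in this assay, at which 1 of the 4 values shown sits. The position does accept a single sulfur atom with a readable response, as compound 4 gives 10 uM.

On these data alone, whether a methylthio group or a longer thioether chain at this carbon would change the number remains open. So does the response to a methylamino group there.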